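Swapping one aromatic group on a low-potency lactone

The compounds below may be only part of what the source reports. "The series", "measured", "known", "first", "only" and "open" are said of these compounds alone.

- compound 1 `O=C1OC[C@H](Cc2ccccc2)[C@H]1Cc1ccc(Cl)c(Cl)c1` gives 19000 nM
- compound 2 `C[C@H](Cc1ccccc1)[C@H](C)Cc1ccc(Cl)c(Cl)c1` gives 19000 nM
- compound 3 `Cc1cccc(C[C@H]2COC(=O)[C@@H]2Cc2ccc(Cl)c(Cl)c2)c1` gives 22000 nM

All three values come from a functional assay on HL-60 cells (Homo sapiens) for cytotoxicity, read by WST assay, with a stated time of 48 h (a higher number here means that more compound is needed for the effect, a lower number that less compound is needed), and lie within the usual scatter of one another. Compound 3 therefore stands level with compound 1 and compound 2, and none of the three can be ranked above the others.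

The unmeasured compound 4 `O=C1OC[C@H](Cc2ccc(F)cc2)[C@H]1Cc1ccc(Cl)c(Cl)c1` differs from compound 3 in one group, with 4-fluorophenyl in place of 3-methylphenyl on a saturated chain carbon bound to a saturated ring carbon.

For the measured compounds named here, only one measured step bears on this change. It is a 1.2-fold higher number from compound 1 to compound 3 (0.06 log units; within the scatter), a methyl in place of hydrogen on an aromatic carbon. That step is small and stays within the scatter, so adding the methyl group made no visible difference in this assay. Going by the values given here, no measured compound carries a fluorine, so the data cannot speak to that atom directly, and this leaves some uncertainty.

Among the compounds with values here, with only this evidence, no change beyond the scatter is expected. The expected step is a 1.1-fold lower number from compound 3 to compound 4 (0.04 log units; within the scatter), with no firm direction.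

The estimate for compound 4 is 20000 nM, with an expected range from 11000 nM to 36000 nM.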

Compound 4, half-maximal effective concentration: 14000 nM
Beside the measured number, compound 4's estimate is 1.4-fold (0.15 log units) above it; the range from low to high includes it.
By their numbers in this assay, from the lowest: compounds 4, 1, 2 and 3 (each within the scatter of the next).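

In this assay, putting 4-fluorophenyl in place of 3-methylphenyl on a saturated chain carbon bound to a saturated ring carbon gives a 1.6-fold lower number from compound 3 to compound 4 (0.20 log units; within the scatter). For the compounds shown here, this is the first look at a fluorine on this aromatic ring, and the direct comparison with the unsubstituted parent gives a 1.4-fold lower number from compound 1 to compound 4 (0.13 log units; within the scatter). Together with the methyl step (a 1.2-fold higher number from compound 1 to compound 3 (0.06 log units; within the scatter)), this shows that neither small substituent moves the number beyond the usual scatter, and that exchanging one for the other, with the heavy-atom count of the group unchanged, does not do so either; no measurement is available that would explain these results.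

The compounds shown leave open whether this aromatic ring tolerates any substituent freely or whether only small ones such as methyl and fluoro leave the number unmoved. A primary amine, a carboxylic acid or a longer chain on that ring could test this, as could a second fluorine or a chlorine in another ring location.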